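This account rests on a few compounds, and the source may have more. Where it says the series, first, only, none or still open, it means among the compounds named here.

Measured so far in a functional assay on MCF7 cells (Homo sapiens) for inhibition, read by MTT assay, with a stated time of 72 h; on this read-out lower numbers stand for stronger inhibition and higher numbers for weaker inhibition:
- compound 1 `Cc1cc(Nc2cc(-c3ccccc3)[nH]n2)n2nc(SCc3ccc(Br)cc3)nc2n1`: 2720 nM
- compound 2 `Cc1cc(Nc2cc(-c3ccccc3)[nH]n2)n2nc(SCc3csc4ccccc34)nc2n1`: 3470 nM

Compound 2 stands level with compound 1 within the scatter. Going by the values given here, the only measured step is a 1.3-fold higher number from compound 1 to compound 2 (0.11 log units; within the scatter), and it exchanges 4-bromophenyl for 1-benzothiophen-3-yl while the sulfur and the saturated chain carbon stay in place.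

Next comes compound 3 `Cc1cc(Nc2cc(-c3ccccc3)[nH]n2)n2ncnc2n1`, with the change (hydrogen in place of ((1-benzothiophen-3-yl)methyl)sulfanyl on an aromatic carbon), which is hydrogen in place of ((1-benzothiophen-3-yl)methyl)sulfanyl on an aromatic carbon. This is a much larger edit than the measured one, since the whole substituent goes. The step to compound 2 therefore bears on it only weakly. Among the compounds with values here, it shows that these two end groups read alike, but no measured compound lacks the substituent, so the data do not size its removal. A moderate move towards a higher number in this assay is expected, with wide uncertainty, and no change beyond the scatter remains possible. The expected step is a 2.0-fold higher number from compound 2 to compound 3 (0.30 log units; within the scatter). For compound 3 the estimated value is 7000 nM, with an expected range from 2500 nM to 25000 nM.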

Compound 3, half-maximal inhibitory concentration: > 50000 nM
Compound 3 gave a limit, no number; the forecaster's own chance of this, stated with the estimate: 15%; at least 7.1-fold (0.85 log units) between middle value and limit.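

The position on the aromatic carbon between two ring nitrogen atoms now proves to matter in this assay: with hydrogen in place of ((1-benzothiophen-3-yl)methyl)sulfanyl the result is an at least 14-fold higher number from compound 2 to compound 3 (1.15 log units; beyond the scatter), and with hydrogen in place of (4-bromobenzyl)sulfanyl it is an at least 18-fold higher number from compound 1 to compound 3 (1.26 log units; beyond the scatter). Compound 1 and compound 2 showed only that two different aromatic end groups on the sulfur and the saturated chain carbon read alike, whereas these two steps, both beyond the scatter, show that measurable inhibition in this series depends on a substituent being present at this place. The reading for compound 3 is a limit and not a number, so the full size of the loss stays undefined: the limit of > 50000 nM in this assay, at which 1 of the 3 values shown sits.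

Still open, on these data alone, is which part of the departed substituent counts: the sulfur, the saturated chain carbon or the aromatic end. A bare methylsulfanyl group, or an amine at the same carbon, would help to separate these parts, and the cause of the loss remains unknown from these three compounds alone.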